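Cytotoxicity of an Iodo to Nitrophenyl Swap on the Shared Core

This account rests on a few compounds, and the source may have more. Where it says the series, first, only, none or still open, it means among the compounds named here.

Compound 3 `Cc1cc(I)cn2c(CSCCc3ccccc3)cnc12` gives only a limit of the assay in an ADME assay on HEL cells (Homo sapiens) for cytotoxicity, with a stated time of 3 days (on this read-out lower numbers stand for higher toxicity in this test and higher numbers for lower toxicity in this test), namely > 50 ug/mL. Compound 2 `Cc1cc(-c2cccc(C#N)c2)cn2c(CSCCc3ccccc3)cnc12` likewise gives only a limit in this assay, > 50 ug/mL. Compound 1 `COc1cccc(-c2cc(C)c3ncc(CSCCc4ccccc4)n3c2)c1` gives 36 ug/mL in this assay, and the limit of > 50 ug/mL in this assay, at which 2 of the 3 values shown sit, marks where the other two values stand. Compound 4 `Cc1cc(-c2cccc([N+](=O)[O-])c2)cn2c(CSCCc3ccccc3)cnc12` differs from compound 3 by 3-nitrophenyl in place of iodo on an aromatic carbon. The measured steps that bear on this change are an at least 1.3-fold higher number from compound 1 to compound 3 (0.14 log units; that floor lies within the scatter), an at least 1.3-fold higher number from compound 1 to compound 2 (0.14 log units; that floor lies within the scatter) and a step that the two limits leave unreadable from compound 2 to compound 3, so no step beyond the scatter is seen among these groups. Compound 2 carries 3-cyanophenyl on the same aromatic carbon. Compound 4 is therefore expected to give 50 ug/mL, between 30 ug/mL and 100 ug/mL, most likely again a limit, an expected step of a number no higher from compound 3 to compound 4 (the limit leaves the size open).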

Compound 4, half-maximal cytotoxic concentration: 43 ug/mL
Compound 4: middle estimate off by 1.2-fold (0.07 log units), on the high side; the range from low to high includes it.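

In this assay, 3-nitrophenyl in place of iodo on this aromatic carbon gives an at least 1.1-fold lower number from compound 3 to compound 4 (0.06 log units; that floor lies within the scatter), and nitro in place of cyano gives an at least 1.1-fold lower number from compound 2 to compound 4 (0.06 log units; that floor lies within the scatter). Nitro in place of methoxy gives a 1.2-fold higher number from compound 1 to compound 4 (0.08 log units; within the scatter), so this read-out does not separate iodo or the three substituted phenyl groups at this position, even with a second measured number now in hand.

As far as these compounds go, compound 2 and compound 3 each give only a limit of the assay, so the full size of their steps stays open: the limit of > 50 ug/mL in this assay, at which 2 of the 4 values shown sit. Whether an amine or a carboxylic acid on this carbon would give a step beyond the scatter also remains open.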